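The source may report more compounds than this note shows. Statements on the series, on what has been measured and on what is new or still open speak of the compounds shown alone.

In a functional assay on HT-1080 cells (Homo sapiens) for cytotoxicity, read by MTT assay, with a stated time of 72 h (on this read-out lower numbers stand for stronger inhibition and higher numbers for weaker inhibition), compound 1 `COc1ccc(/C=C2\CCC/C(=C\c3ccc(OC)c(OC)c3)C2=O)cc1` gives 7200 nM, and compound 2 `COc1ccc(/C=C2\CCC/C(=C\c3ccc(Cl)c(Cl)c3)C2=O)cc1OC` gives 3100 nM, the lower of the two numbers. Compound 3 `COc1ccc(/C=C2\CCC/C(=C\c3ccc(O)c(Cl)c3)C2=O)cc1OC` differs from compound 2 in one place: hydroxy in place of chloro on an aromatic carbon. This puts hydroxy in place of chloro on an aromatic carbon, turning 3,4-dichlorophenyl into 3-chloro-4-hydroxyphenyl. Among the compounds with values here, the only measured step involving this group is modest: a 2.3-fold lower number from compound 1 to compound 2 (0.37 log units; beyond the scatter), when 3,4-dichlorophenyl replaced 4-methoxyphenyl. With one chloro leaving, part of that drop may be lost, so a small rise is expected: a 1.3-fold higher number from compound 2 to compound 3 (0.11 log units; within the scatter). For compound 3, the estimated value is 4000 nM, within an expected range of 1300 nM to 12000 nM.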

Compound 3, half-maximal inhibitory concentration: 7600 nM
Estimate against measurement, compound 3: 1.9-fold (0.28 log units) below, and the stated range covers the measured number.
By their numbers in this assay, from the lowest: compound 2; then compounds 1 and 3 (each within the scatter of the next).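

In this assay, this position on the ring is sensitive to the group it carries: hydroxy in place of chloro gives a 2.5-fold higher number from compound 2 to compound 3 (0.39 log units; beyond the scatter) and so loses the advantage of 3,4-dichlorophenyl. Set against 4-methoxyphenyl, 3-chloro-4-hydroxyphenyl gives a 1.1-fold higher number from compound 1 to compound 3 (0.02 log units; within the scatter) and cannot be told apart from it here. Nothing measured here explains why swapping chloro for hydroxy raises the number. Still open, from the compounds shown here alone, is how an amine or a carboxylic acid would behave at this position with the neighbouring chloro kept. Whether bromo or fluoro would match chloro also remains unanswered.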